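Ethoxy for Methoxy on a Shared Core: Expected Stability

The compounds below may be only part of what the source reports. "The series", "measured", "known", "first", "only" and "open" are said of these compounds alone.

Measured compounds:
compound 1, `COc1ccc(-n2cnc3cnc(-c4ccc(F)cc4C)cc32)cc1OC`, gives 1.
compound 2, `COc1ccc(-n2cnc3cnc(-c4cc(F)ccc4C)cc32)cc1OC`, gives 1.
compound 3, `COc1ccc(-n2cnc3cnc(-c4ccc(F)cc4C)cc32)cc1`, gives 1.

All three were measured in an ADME assay on S9 fraction from liver (Mus musculus) for metabolic stability, read by LC-MS, using NADPH, with a stated time of 45 min, tested at 3 uM, in the presence of a further agent that is not named here; on this read-out higher numbers stand for higher hepatic extraction and lower numbers for lower hepatic extraction. Compound 3 stands level with compounds 1 and 2 at the digits shown: the step of no change at the digits printed from compound 1 to compound 3 (within the scatter) is within the scatter, and so is the step of no change at the digits printed from compound 1 to compound 2 (within the scatter). Moving a fluorine on one aromatic ring, or removing a methoxy from the other, left the read-out unchanged.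

The next compound, compound 4, `CCOc1ccc(-n2cnc3cnc(-c4ccc(F)cc4C)cc32)cc1`, differs from compound 3 by methyl in place of hydrogen on a saturated chain carbon bound to an oxygen on an aromatic ring. Among the measured compounds shown here, no measured step touches this exact change; the nearest is the step from compound 1 to compound 3, which altered the same oxygen-bearing part of the molecule and showed no movement. The other step, between compounds 1 and 2, also showed none. Every measured value sits at the same level, so the expectation for this assay is a step of no size beyond the scatter: for compound 4 the estimated step is no change at the digits printed from compound 3 to compound 4 (within the scatter). The estimated value for compound 4 is 1, with a range from 0.9 to 1.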

Compound 4, hepatic extraction ratio: 0.97
The estimate for compound 4 lay 0.030 above the measured number, and the stated range covers the measured number.
By their numbers in this assay, from the lowest: compounds 4, 1, 2 and 3 (each within the scatter of the next).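

In this assay, adding a methyl to the saturated chain carbon bound to an oxygen on an aromatic ring, which turns methoxy into ethoxy, gives a number 0.030 lower from compound 3 to compound 4 (within the scatter). The earlier steps shown here moved a fluorine and removed a whole methoxy, whereas this one extends the group that stays on the ring, and compound 4 at 0.97 still sits close to the whole of the fraction scale, so a methoxy-to-ethoxy change at this place gives no sign of lower hepatic extraction. Nothing measured here offers an explanation for this flat result.

As far as these compounds go, what remains open is whether any group at this place can bring the read-out clearly down, such as a longer chain ending in an amine or a carboxylic acid. All four compounds stand so close together that they also leave unsettled which part of the shared core, if any, governs the read-out in this assay.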